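This account rests on a few compounds, and the source may have more. Where it says the series, first, only, none or still open, it means among the compounds named here.

Measured compounds:
compound 1 `C#CCNC1CCc2c(NCc3cccc(Br)c3)cccc21`: 94300 nM in an ADME assay on cells for inhibition of Amine oxidase [flavin-containing] A (Homo sapiens), read by fluorescence and Amplex Red, with stated times of 30 min and 15 min; a lower number here means a stronger inhibitor, a higher number a weaker inhibitor
compound 2 `C#CCNC1CCc2c(OCCc3cc(NC(=O)C(C)(C)C)ccc3F)cccc21`: "not determined" (no result reported) in this assay
compound 3 `C#CCNC1CCc2c(OCCc3cc(NC(=O)c4cccc(F)c4)ccc3Cl)cccc21`: "not determined" (no result reported) in this assay

Compound 1 gives 94300 nM in this assay, which marks it as a weak inhibitor. Compound 3 gives "not determined" (no result reported) in this assay, and compound 2 likewise gives "not determined" (no result reported), so compound 3 cannot be placed against any measured value of the series. Compound 4 `C#CCNC1CCc2c(OCCc3cc(NC(=O)COC(C)=O)ccc3Cl)cccc21` differs from compound 3 by acetoxymethyl in place of 3-fluorophenyl on a carbonyl carbon. Among the measured compounds shown here, no step between measured compounds exists to set the size of this change; the only measured value belongs to compound 1 with 94300 nM, and weak inhibition is expected to persist, with no shift expected beyond the scatter. Compound 4 is therefore estimated at 60000 nM, within a range of 8000 nM to 400000 nM.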

Compound 4, half-maximal inhibitory concentration: 437000 nM
The estimate for compound 4 lay 7.3-fold (0.86 log units) below the measured number; measured number above the stated range.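

Among the compounds shown here, with compound 3 carrying no single number in this assay, no step from it to compound 4 can be read. The compounds shown leave open how acetoxymethyl and 3-fluorophenyl compare on the carbonyl carbon. Nothing given here offers an explanation of the value of compound 4.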